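The source may report more compounds than this note shows. Statements on the series, on what has been measured and on what is new or still open speak of the compounds shown alone.

Measured so far in an ADME assay on Caco-2 cells (Homo sapiens) for permeability, in the apical to basolateral direction; on this read-out lower numbers stand for lower permeability and higher numbers for higher permeability:
- compound 1, `Cn1nc2c(=O)n(CC3(O)CCN(Cc4ccc(-c5ccco5)cc4Cl)CC3)cnc2c1-c1ccc(C2(N)CC2)cc1`: 1.99 10^-6 cm/s
- compound 2, `Cn1nc2c(=O)n(CC3(O)CCN(Cc4ccc(-c5ccco5)cc4Cl)CC3)cnc2c1-c1ccc(F)cc1`: 6.84 10^-6 cm/s
- compound 3, `Cn1nc2c(=O)n(CC3(O)CCN(Cc4ccc(-c5cnco5)cc4Cl)CC3)cnc2c1-c1ccc(CN)cc1`: 0.86 10^-6 cm/s

Compound 2 gives the highest number of the three; compound 1 is nearest, compound 3 furthest, both beyond the scatter. Within the data shown here, the one step within the measured set that is a single change is a 3.4-fold higher number from compound 1 to compound 2 (0.54 log units; beyond the scatter), a modest gain when the primary amine bearing group leaves and fluoro enters.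

Compound 4, `Cn1nc2c(=O)n(CC3(O)CCN(Cc4ccc(-c5ccco5)cc4Cl)CC3)cnc2c1-c1ccc(CN)cc1`, reverses that direction: aminomethyl in place of fluoro on an aromatic carbon. Among the measured compounds shown here, the only step that bears on it is the one from compound 1 to compound 2, read backwards, and it was modest but beyond the scatter. For the measured compounds named here, compound 3 also carries aminomethyl on the same ring, with a second difference elsewhere, and stands lowest; this is consistent with a drop but no step is computed for that pair. A decrease beyond the scatter is therefore expected in this assay, of roughly the size seen between compound 1 and compound 2, so the expected step is a 4.0-fold lower number from compound 2 to compound 4 (0.60 log units; beyond the scatter). Compound 4 is estimated at 1.7 10^-6 cm/s, with a range from 0.7 10^-6 cm/s to 4 10^-6 cm/s.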

Compound 4, apparent permeability: 0.92 10^-6 cm/s
Estimate against measurement, compound 4: 1.8-fold (0.27 log units) above; the range from low to high includes it.
By their numbers in this assay, from the lowest: compounds 3 and 4 (each within the scatter of the next); then compound 1; then compound 2.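

In this assay, the direct exchange at this position gives a 7.4-fold lower number from compound 2 to compound 4 (0.87 log units; beyond the scatter) with aminomethyl in place of fluoro, so both amine-bearing groups shown now stand below fluoro on this ring. The two amine-bearing groups are also separated from each other, as aminomethyl in place of 1-aminocyclopropyl gives a 2.2-fold lower number from compound 1 to compound 4 (0.34 log units; beyond the scatter) with the rest of the structure unchanged. With aminomethyl held fixed, furan-2-yl in place of 1,3-oxazol-5-yl gives a 1.1-fold higher number from compound 3 to compound 4 (0.03 log units; within the scatter) and leaves the two numbers within the scatter of each other.

Nothing shown accounts for these differences.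

Still open, going by these compounds, is where a hydroxymethyl group, a carboxylic acid or a longer aminoethyl chain would fall at this position, and whether the exchange of furan-2-yl for 1,3-oxazol-5-yl gives the same result with fluoro on the ring.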